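A few compounds are considered here, and "the series" means these few. Any claim that something is new, unique, unknown or untested is made for them only; others in the source may bear on it.

Measured so far:
- Compound 1 `FC(F)(F)c1ccc(-c2nn(-c3ccccc3)cc2-c2nc3ccccc3[nH]2)cc1`: 3620 nM
- Compound 2 `O=S(=O)(c1ccccc1)n1c(-c2cn(-c3ccccc3)nc2-c2ccc(C(F)(F)F)cc2)nc2ccccc21`: 480 nM
- Compound 3 `O=[N+]([O-])c1ccc(S(=O)(=O)n2c(-c3cn(-c4ccccc4)nc3-c3ccc(C(F)(F)F)cc3)nc3ccccc32)cc1`: 790 nM

In a functional assay on A549 cells (Homo sapiens) for antiproliferative activity, read by MTT assay, with a stated time of 24 h (on this read-out higher numbers stand for weaker inhibition and lower numbers for stronger inhibition), compound 3 sits close to one relative and clearly apart from the other. The measurements show a 1.6-fold higher number from compound 2 to compound 3 (0.22 log units; within the scatter) and a 4.6-fold lower number from compound 1 to compound 3 (0.66 log units; beyond the scatter).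

Compound 4 `O=S(=O)(c1ccc(C(F)(F)F)cc1)n1c(-c2cn(-c3ccccc3)nc2-c2ccc(C(F)(F)F)cc2)nc2ccccc21` differs from compound 3 at a single place: trifluoromethyl in place of nitro on an aromatic carbon. This is trifluoromethyl in place of nitro on an aromatic carbon, para to a large group.

The closest evidence comes from that same place, where nitro replaced hydrogen, and it shows a 1.6-fold higher number from compound 2 to compound 3 (0.22 log units; within the scatter). The larger change, a 7.5-fold lower number from compound 1 to compound 2 (0.88 log units; beyond the scatter), concerns the sulfonyl group, which compound 4 retains. That single example at the changing place gives little to go on, but it points to no step beyond the scatter in this assay.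

The expected result is a 1.3-fold lower number from compound 3 to compound 4 (0.11 log units; within the scatter). Compound 4 is estimated at 620 nM, with an expected range of 280 nM to 1350 nM.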

Compound 4, half-maximal inhibitory concentration: 860 nM
Estimate against measurement, compound 4: 1.4-fold (0.14 log units) below; measured number inside the range.
By their numbers in this assay, from the lowest: compounds 2, 3 and 4 (each within the scatter of the next); then compound 1.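

In this assay the swap of 4-nitrophenyl to 4-(trifluoromethyl)phenyl gives a 1.1-fold higher number from compound 3 to compound 4 (0.04 log units; within the scatter) and so a second, different group on this aromatic carbon, para to a large group, also stays within the scatter. Trifluoromethyl in place of hydrogen gives a 1.8-fold higher number from compound 2 to compound 4 (0.25 log units; within the scatter) and this leaves compounds 2, 3 and 4 with no order among them, since hydrogen, nitro and trifluoromethyl at this place cannot be told apart here. Nothing measured on these compounds accounts for this result.

From the compounds shown here alone, it remains open whether an amine, a carboxylic acid or a longer chain such as butyl at this place would also stay within the scatter. A group on one of the other carbons of this ring is equally untested by the compounds shown.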